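From a Halogenated Phenyl Ring to Thiophene

The source may report more compounds than this note shows. Statements on the series, on what has been measured and on what is new or still open speak of the compounds shown alone.

The compounds measured in a functional assay on A549 cells (Homo sapiens) for cytotoxicity, read by MTT assay, with a stated time of 72 h (on this read-out higher numbers stand for weaker inhibition and lower numbers for stronger inhibition), are:
Compound 1, `COc1cc2c(Oc3ccc(NC(=O)N/N=C/c4ccc(C(F)(F)F)cc4)cc3F)ccnc2cc1OCCCN1CCCCC1`, gives 660 nM.
Compound 2, `COc1cc2c(Oc3ccc(NC(=O)N/N=C/c4ccc(F)cc4Cl)cc3F)ccnc2cc1OCCCN1CCCCC1`, gives 130 nM.
Compound 3, `COc1cc2c(Oc3ccc(NC(=O)N/N=C/c4ccc(Cl)cc4Cl)cc3F)ccnc2cc1OCCCN1CCCCC1`, gives "not determined" (no result reported), that is, no result was reported for it.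

Going by the values given here, only one measured step exists, a 5.1-fold lower number from compound 1 to compound 2 (0.71 log units; beyond the scatter), and it leaves compound 2 with the lowest number among the two compounds for which a value was obtained.

Compound 4, `COc1cc2c(Oc3ccc(NC(=O)N/N=C/c4cccs4)cc3F)ccnc2cc1OCCCN1CCCCC1`, has not been measured. Set against compound 2, the change is this: thiophen-2-yl in place of 2-chloro-4-fluorophenyl on a carbon with a double bond to nitrogen. Among the compounds with values here, the one measured step swapped substituents on a six-membered ring while keeping that ring; here the ring itself is exchanged, so that step bears on the present change only loosely, and no other comparison is available. With so little to lean on, the expectation for compound 4 is a step of a 2.3-fold higher number from compound 2 to compound 4 (0.36 log units; beyond the scatter) in this assay, toward a higher number but not far beyond the scatter. Compound 4 is therefore estimated at 300 nM, with a range from 100 nM to 1000 nM.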

Compound 4, half-maximal inhibitory concentration: 790 nM
Estimate against measurement, compound 4: 2.6-fold (0.42 log units) below, within the range that was stated.
By their numbers in this assay, from the lowest: compound 2; then compounds 1 and 4 (each within the scatter of the next).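

In this assay, exchanging the whole ring on the carbon with a double bond to nitrogen gives a 6.1-fold higher number from compound 2 to compound 4 (0.78 log units; beyond the scatter) and shows that this position responds to a change of ring, not only to a swap of substituents on a six-membered ring. The other step is a 1.2-fold higher number from compound 1 to compound 4 (0.08 log units; within the scatter) and links a five-membered ring with a six-membered one, so ring size alone does not separate these numbers, and among the three compounds with a value only the 2-chloro-4-fluorophenyl group of compound 2 stands apart. Nothing measured here explains these differences.

Thiophen-2-yl differs from 2-chloro-4-fluorophenyl both in its ring and in carrying no halogen, so the compounds shown do not say which of the two matters. A plain phenyl ring or a furan-2-yl ring on the same carbon would bear on that question.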